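This account rests on a few compounds, and the source may have more. Where it says the series, first, only, none or still open, it means among the compounds named here.

Measured compounds:
- compound 1, `COc1c(OCCCCN2CCCC2)cc(O)c2c(=O)cc(-c3ccccc3)oc12`, gives 1530 nM in a functional assay on A549 cells (Homo sapiens) for cytotoxicity, read by MTT assay, with a stated time of 48 h; on this read-out lower numbers stand for stronger inhibition and higher numbers for weaker inhibition
- compound 2, `COc1c(O)cc(O)c2c(=O)cc(-c3cccc(F)c3)oc12`, gives "not determined" (no result reported) in this assay
- compound 3, `CCCNCCOc1c(O)cc(O)c2c(=O)cc(-c3ccccc3)oc12`, gives "not determined" (no result reported) in this assay

Among the measured compounds shown here, compound 1 therefore stands alone: its value is the only number in this assay, and nothing can be said about how it ranks against compound 2 or compound 3, for which no result was reported.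

Compound 4, `COc1c(OCCCCN2CCN(C)CC2)cc(O)c2c(=O)cc(-c3ccccc3)oc12`, has not yet been measured. It differs from compound 1 in one place: 4-methylpiperazin-1-yl in place of pyrrolidin-1-yl on a saturated chain carbon, four bonds along the chain from an oxygen on an aromatic ring. The rest of the shared core, the chain and the ring attached to it are unchanged.

For the measured compounds named here, no measured pair in this set shows what such an exchange does, so the expectation rests on compound 1 alone. A change of this kind, one ring amine for another at the end of the chain, is expected to move this assay little, with no clear direction beyond the scatter, perhaps a slight drift toward weaker inhibition.

For compound 4, the estimated step from compound 1 is a 1.3-fold higher number from compound 1 to compound 4 (0.12 log units; within the scatter). Compound 4 is expected to give about 2000 nM, in a range from 700 nM to 6000 nM.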

Compound 4, half-maximal inhibitory concentration: 1500 nM
Beside the measured number, compound 4's estimate is 1.3-fold (0.12 log units) above it; low and high end bracket the measured number.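

In this assay, 4-methylpiperazin-1-yl in place of pyrrolidin-1-yl on a saturated chain carbon, four bonds along the chain from an oxygen on an aromatic ring, gives a 1.0-fold lower number from compound 1 to compound 4 (0.01 log units; within the scatter). Among the compounds shown here, this is the first comparison at this position, and it shows that a six-membered ring with two hetero atoms and a five-membered ring with one cannot be told apart here by this read-out. No measurement shown speaks to why these two groups read alike.

Going by these compounds, only these two ring amines can be compared at the chain end, so it remains open whether a morpholin-4-yl ring, an open-chain diethylamino group or a carboxylic acid would read the same. On these data alone, it is also open whether a longer or shorter chain carrying the same rings would keep this match.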